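This account rests on a few compounds, and the source may have more. Where it says the series, first, only, none or still open, it means among the compounds named here.

Working notes on the series, starting from compound 2 (`O=C(O)c1cc(-c2ccc(Oc3ccccc3)cc2)nn1C1CCCN(C(=O)CCl)C1`). In a functional assay on Rec1 cells (Homo sapiens) for inhibition, read by luminescence and CellTiter-Glo, with a stated time of 72 h (on this read-out higher numbers stand for weaker inhibition and lower numbers for stronger inhibition), compound 2 gives 2200 nM. Compound 3 (`O=C(CCl)Nc1ccc(Cn2nc(-c3ccc(Oc4ccccc4)cc3)cc2C(=O)O)cc1`) gives 4000 nM, and these two values lie within the scatter of each other. Compound 1 (`O=C(CCl)N1CCCC(n2nc(-c3ccc(Oc4ccccc4)cc3)cc2CO)C1`) gives 400 nM, clearly the lowest number of the three, so compound 2 sits with compound 3 at the weaker end of this small set.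

The next change leads to compound 4 (`C/C=C/C(=O)N1CCCC(n2nc(-c3ccc(Oc4ccccc4)cc3)cc2C(=O)O)C1`), with prop-1-en-1-yl in place of chloromethyl on a carbonyl carbon.

For the measured compounds named here, all three measured compounds carry chloromethyl, so no measured step touches this position. Going by the values given here, the only measured step, a 5.5-fold higher number from compound 1 to compound 2 (0.74 log units; beyond the scatter), is modest and comes from carboxy in place of hydroxymethyl on an aromatic carbon. It bears on the new change only indirectly, as a guide to how far a single change has moved the number in this series.

In this assay, a small shift towards a higher number is expected, without a clear move beyond the scatter. The expected step is a 1.8-fold higher number from compound 2 to compound 4 (0.26 log units; within the scatter). The uncertainty is wide, given the absence of direct evidence. For compound 4 the estimate is 4000 nM, with an expected range of 1300 nM to 13000 nM.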

Compound 4, half-maximal inhibitory concentration: 31000 nM
For compound 4 the middle estimate is 7.8-fold (0.89 log units) below the measured one; measured number outside the range, above it.
By their numbers in this assay, from the lowest: compound 1; then compounds 2 and 3 (each within the scatter of the next); then compound 4.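

For the compounds shown here, this is the first measured change at the carbonyl carbon on the amide-type nitrogen in a ring, and in this assay it gives a large step, a 14-fold higher number from compound 2 to compound 4 (1.15 log units; beyond the scatter), for prop-1-en-1-yl in place of chloromethyl. The position therefore affects the number in this series, and this single exchange is the larger of the two listed steps: the change from hydroxymethyl to carboxy on an aromatic carbon, a 5.5-fold higher number from compound 1 to compound 2 (0.74 log units; beyond the scatter), is rated modest, while this one is rated large. Nothing available accounts for the size of the step at this carbonyl carbon.

The compounds shown leave open whether the same exchange carries a comparable step on the hydroxymethyl compound 1, since the step is read here only with the carboxy group of compound 2 and compound 4 in place. They also leave open how the number responds to other groups on this carbonyl carbon, such as ethenyl, a dimethylaminomethyl-bearing ethenyl chain or a saturated propyl chain, so one exchange does not yet describe the position as a whole.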